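The source may report more compounds than this note shows. Statements on the series, on what has been measured and on what is new or still open speak of the compounds shown alone.

Measured compounds, all in an assay on isolated protein for inhibition of Retinaldehyde dehydrogenase 3 (Homo sapiens); a lower number here means a stronger inhibitor, a higher number a weaker inhibitor:
- compound 1, `Cn1ncc2c(=O)n(-c3ccccc3)c(SC(C)(C)c3ccccc3)nc21`: 1390 nM
- compound 2, `CC(Sc1nc2c(cnn2C)c(=O)n1-c1ccccc1)c1cccc(O)c1`: 91 nM
- compound 3, `CC(Sc1nc2c(cnn2C)c(=O)n1-c1ccccc1)c1cncnc1`: 100 nM

Compound 3 sits second highest of the three numbers in this assay; its nearest neighbour is compound 2, from which it is separated only by a 1.1-fold higher number from compound 2 to compound 3 (0.04 log units; within the scatter), a gap within the scatter, while compound 1 lies far above it, as a 14-fold lower number from compound 1 to compound 3 (1.14 log units; beyond the scatter) shows.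

Compound 4, `C[C@H](Sc1nc2c(cnn2C)c(=O)n1-c1ccccc1)c1ccccc1`, is not yet measured. It differs from compound 3 by 1-phenylethyl in place of 1-(pyrimidin-5-yl)ethyl on a sulfur.

Among the compounds with values here, two measured steps bear on this change. The step of a 14-fold lower number from compound 1 to compound 3 (1.14 log units; beyond the scatter) covers the same pair of aryl groups but is confounded with the loss of a methyl on the chain carbon, so it cannot be read as the aryl swap alone. The step of a 1.1-fold higher number from compound 2 to compound 3 (0.04 log units; within the scatter) shows that exchanging the pyrimidinyl for a hydroxyphenyl on the same chain carbon left the number essentially unchanged. Going by these compounds, removing both ring nitrogens without adding the hydroxyl is untested, so the size of the step in this assay is uncertain; a moderate rise toward compound 1, short of its value, is the working expectation.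

Compound 4 is therefore expected at 250 nM, within 80 nM to 800 nM, implying an estimated step of a 2.5-fold higher number from compound 3 to compound 4 (0.40 log units; beyond the scatter).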

Compound 4, half-maximal inhibitory concentration: 1640 nM
For compound 4 the middle estimate is 6.6-fold (0.82 log units) below the measured one; measured number outside the range, above it.
By their numbers in this assay, from the lowest: compounds 2 and 3 (each within the scatter of the next); then compounds 1 and 4 (each within the scatter of the next).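

In this assay, the unsubstituted phenyl ring is the outlier at this position on the chain carbon: a 16-fold higher number from compound 3 to compound 4 (1.21 log units; beyond the scatter) and an 18-fold higher number from compound 2 to compound 4 (1.26 log units; beyond the scatter) show that either the two ring nitrogens of the pyrimidin-5-yl or the hydroxyl of the 3-hydroxyphenyl goes with a much lower number than 1-phenylethyl gives. The extra methyl on the chain carbon, which confounded the earlier comparison, makes no difference that can be read with a phenyl ring in place, a 1.2-fold higher number from compound 1 to compound 4 (0.07 log units; within the scatter), so the earlier 14-fold lower number from compound 1 to compound 3 (1.14 log units; beyond the scatter) travels with the aryl group rather than with that methyl. Nothing shown explains why these aryl groups differ so sharply.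

Still open, going by these compounds, is how much a single ring nitrogen, as in pyridin-3-yl, or a replacement for the hydroxyl such as methoxy or an amine, would recover of the number held by compound 2 and compound 3. On these data alone, compound 4 also carries a defined stereocentre that compound 2 and compound 3 do not show, so the reading of its opposite configuration remains open.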